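The source may report more compounds than this note shows. Statements on the series, on what has been measured and on what is new or still open speak of the compounds shown alone.

Within the data shown here, in an assay on isolated protein (Mus musculus) for inhibition of IL15-IL15 receptor (Homo sapiens), read by resazurin assay, with stated times of 30 min and 2.5 days (a lower number here means a stronger inhibitor, a higher number a weaker inhibitor), compound 1 `CC(C)COc1ccc(NC(=O)CCCCCCCSc2nnc(Cc3nn(C)c(=O)c4ccccc34)n2C)cc1` gives 4800 nM, the second highest of the three numbers measured so far. Compound 2 `Cn1c(Cc2nn(C)c(=O)c3ccccc23)nnc1SCCCC(=O)Nc1ccc(Cl)cc1Cl` gives 9800 nM, a higher number whose gap to compound 1 lies beyond the scatter, and compound 3 `Cn1c(Cc2nn(C)c(=O)c3ccccc23)nnc1S(=O)(=O)CCCCCCCC(=O)Nc1ccc(Br)cc1Br` gives 1400 nM, a lower number whose gap to compound 1 also lies beyond the scatter. Compound 4 `Cn1c(Cc2nn(C)c(=O)c3ccccc23)nnc1SCCCCCCCC(=O)Nc1ccc(F)cc1F` has not yet been measured in this assay. It differs from compound 1 by 2,4-difluorophenyl in place of 4-(isobutoxy)phenyl on an amide-type nitrogen. Since the values of compound 2 and compound 3 sit on either side of compound 1, no step beyond the scatter is expected for this change. Compound 4 is therefore estimated at 5000 nM, within a range from 1500 nM to 16000 nM. The step of a 1.0-fold higher number from compound 1 to compound 4 (0.02 log units; within the scatter) is expected to be small.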

Compound 4, half-maximal inhibitory concentration: 2300 nM
Compound 4: middle estimate off by 2.2-fold (0.34 log units), on the high side; measured number inside the range.
By their numbers in this assay, from the lowest: compounds 3 and 4 (each within the scatter of the next); then compound 1; then compound 2.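

Replacing 4-(isobutoxy)phenyl with 2,4-difluorophenyl on an amide-type nitrogen gives, in this assay, a 2.1-fold lower number from compound 1 to compound 4 (0.32 log units; beyond the scatter). Among these compounds, this is the first comparison that isolates this position, and it shows that the smaller group, which has no hydrogen-bond acceptor, is tolerated with a modest step toward stronger inhibition. No available measurement accounts for the step.

As far as these compounds go, whether the step follows from the fluorine atoms entering or the isobutoxy group leaving remains open. So does the effect of an unsubstituted phenyl or an amine on that ring.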